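A few compounds are considered here, and "the series" means these few. Any claim that something is new, unique, unknown or untested is made for them only; others in the source may bear on it.

Compound 1 `C#CCOc1ccc(-c2cc(-c3ccccc3OCC#C)nc(N)n2)cc1` stands alone with a number in an assay on BTI-TN-5B1-4 cells for inhibition of Amine oxidase [flavin-containing] A (Homo sapiens), read by fluorescence and Amplex Red, using microsomes, with a stated time of 30 min; a higher number here means a weaker inhibitor, a lower number a stronger inhibitor: in this assay compound 1 gives 28600 nM. Compound 2 `C#CCOc1ccc(-c2cc(-c3ccc(OCC#C)c(OCC)c3)nc(-c3ccccc3)n2)cc1` was tested in this assay as well, but for compound 2 the result is reported only as "not active" (no number reported), with no number attached, so it offers no point of comparison and no ranking of the two can be made from it.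

Compound 3 `C#CCOc1ccc(-c2cc(-c3ccccc3OCC#C)nc(C)n2)cc1` has not been measured. It differs from compound 1 in a single spot, the change being (methyl in place of amino on an aromatic carbon), that is, methyl in place of amino on an aromatic carbon of the shared core. Going by the values given here, no pair of measured compounds differing in one place is available, so nothing in these data shows how large a swap of this kind tends to be. With only compound 1 as an anchor, a moderate step toward weaker inhibition seems the most plausible expectation, though a result within the usual scatter would not surprise. The step of a 1.6-fold higher number from compound 1 to compound 3 (0.20 log units; within the scatter) is therefore the estimated change. Compound 3 is expected to give 45000 nM, with a plausible range from 15000 nM to 130000 nM.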

Compound 3, half-maximal inhibitory concentration: 23200 nM
Compound 3: the middle estimate sits 1.9-fold (0.29 log units) above what was measured; the measured number falls inside the stated range.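

Replacing amino with methyl on the aromatic carbon between two ring nitrogen atoms gives, in this assay, a 1.2-fold lower number from compound 1 to compound 3 (0.09 log units; within the scatter), so compound 1 and compound 3 cannot be told apart in this assay. Going by these compounds alone, this is the first step available in this set, and it offers a first sense of how much this position responds to a change: the amino group counts as a hydrogen-bond donor and a hydrogen-bond acceptor and the methyl as neither, yet for this one pair that difference in counts leaves no mark on the read-out beyond the usual scatter. Nothing among the data shown offers an explanation for this result.

Going by these compounds, whether a group of another kind on the same carbon, such as a carboxylic acid, a hydroxyl or a longer chain like propyl, would move the number beyond the scatter stays open. On these data alone, one pair is also a single observation, so it remains unknown whether the same swap would behave alike on a core carrying different large groups.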